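The source may hold more compounds than are shown below. What is called first, only, known or untested is meant among the compounds shown, and "the series" means these compounds.

Compound 2 (`Cc1cn(C2CC(N=[N+]=[N-])C(COC(=O)NCCCN)O2)c(=O)[nH]c1=O`) in a functional assay on MT4 cells (Homo sapiens) for cytotoxicity (a lower number here means that less compound is tolerated, a higher number that more compound is tolerated), gives > 50000 nM, which is a limit of the assay rather than a number. Compound 1 (`Cc1cn(C2CC(N=[N+]=[N-])C(COC(=O)NCCCC(=O)OC(C)(C)C)O2)c(=O)[nH]c1=O`) in this assay gives > 50000 nM, also a limit. Compound 3 (`Cc1cn(C2CC(N=[N+]=[N-])C(COC(=O)CCCN)O2)c(=O)[nH]c1=O`) in this assay gives > 50000 nM, again a limit. The steps a step that the two limits leave unreadable from compound 1 to compound 2 and a step that the two limits leave unreadable from compound 2 to compound 3 are accordingly unreadable in both size and direction, since every measured value sits at the limit of > 50000 nM in this assay, at which 3 of the 3 values shown sit.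

Compound 4 (`Cc1cn(C2CC(N=[N+]=[N-])C(COC(=O)OCCCO)O2)c(=O)[nH]c1=O`) differs from compound 2 by 3-hydroxypropoxy in place of (3-aminopropyl)amino on a carbonyl carbon. Among the measured compounds shown here, no measured step in this assay carries a readable size, and the changes on either side of compound 2 both end at the same limit, so the record gives no measured movement to build on. For compound 4 the expected step is therefore a step that the limit leaves unreadable from compound 2 to compound 4, with no change beyond the scatter expected. The estimate for compound 4 is 100000 nM, with a range from 40000 nM to 300000 nM, and the result is expected most likely to be reported again as a limit.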

Compound 4, half-maximal cytotoxic concentration: > 50000 nM
Compound 4: no number, only a limit (the forecaster's own chance of this, stated with the estimate: 85%); the middle value is on the limit's open side.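

In this assay compound 4 gives > 50000 nM, a limit and not a number, so the steps to compound 4 from compound 2 and compound 3 cannot be read: the limit of > 50000 nM in this assay, at which 4 of the 4 values shown sit.

The compounds shown leave open at what concentration any of them becomes cytotoxic, and whether these changes shift that concentration.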